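A methoxy added to compound 1

This account rests on a few compounds, and the source may have more. Where it says the series, first, only, none or still open, it means among the compounds named here.

Compound 1 (`CCN(CC)CC(Cn1cncn1)NCc1ccccc1`) gives > 300000 nM in an ADME assay on CHO cells (Cricetulus griseus) for cytotoxicity, read by MTT assay (a higher number here means a weaker inhibitor, a lower number a stronger inhibitor), as a limit of the assay and not a number. Compound 2 (`CCN(CC)CC(CN(CC)CC)NCc1ccccc1`) gives > 300000 nM as a limit too. Among the measured compounds shown here, the only measured step (a step that the two limits leave unreadable from compound 1 to compound 2) puts diethylamino in place of 1H-1,2,4-triazol-1-yl on a saturated chain carbon, and it has no readable size. Beyond that step the data hold only the limit of > 300000 nM in this assay, at which 2 of the 2 values shown sit, and so offer no number that could size a change.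

Compound 3 (`CCN(CC)CC(Cn1cncn1)NCc1ccc(OC)cc1`) has not yet been measured. It carries methoxy in place of hydrogen on an aromatic carbon, para to a large group, which is not the place changed in the measured step. With compound 1 at > 300000 nM as a limit, nothing points to a step of any size or direction, so none beyond the scatter is expected. The expected change is a number no higher from compound 1 to compound 3 (the limit leaves the size open) and it is estimated to stay unreadable if only a limit returns. For compound 3 the estimate is 300000 nM with 100000 nM to 600000 nM as its expected range.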

Compound 3, half-maximal inhibitory concentration: 159000 nM
Compound 3: the middle estimate sits 1.9-fold (0.28 log units) above what was measured; low and high end bracket the measured number.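

Compound 3 is the only one of the three compounds shown that returns a number rather than a limit in this assay, which makes the aromatic carbon para to a large group the first place in these compounds where a change can be given any size. Methoxy in place of hydrogen there gives an at least 1.8-fold lower number from compound 1 to compound 3 (0.27 log units; that floor lies within the scatter), so the data hold a floor for this step and not its full size, and that floor alone does not carry the step beyond the usual scatter. The size of the step above that floor cannot be read because its starting point is only a limit: the limit of > 300000 nM in this assay, at which 2 of the 3 values shown sit.

The compounds shown leave open whether a chloro or hydroxy group on the same aromatic carbon would also return a number in this assay, and whether methoxy would do so on another carbon of that ring. They also leave open what methoxy at this place would do on the diethylamino compound 2, whose step from compound 1 cannot be read.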